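Furan-2-yl in place of phenyl: cytotoxicity notes

The compounds below may be only part of what the source reports. "The series", "measured", "known", "first", "only" and "open" are said of these compounds alone.

Measured so far:
compound 1 `COc1ncnc2c1c(I)cn2[C@@H]1O[C@H](CO)[C@@H](O)[C@H]1O` — 91000 nM
compound 2 `Nc1nc2c(c(-c3ccccc3)cn2[C@@H]2O[C@H](CO)[C@@H](O)[C@H]2O)c(=O)[nH]1` — a limit only, > 100000 nM
compound 3 `CNc1ncnc2c1c(-c1ccoc1)cn2[C@@H]1O[C@H](CO)[C@@H](O)[C@H]1O` — 96300 nM

All three sit at the weak end of an ADME assay on BJ cells (Homo sapiens), read by MTT assay, with a stated time of 72 h; on this read-out lower numbers stand for stronger inhibition and higher numbers for weaker inhibition. Compound 1 gives 91000 nM and compound 3 gives 96300 nM. Within the data shown here, compound 2 returns only a limit, > 100000 nM; it is the one compound at the limit of > 100000 nM in this assay, at which 1 of the 3 values shown sits. Compound 4 `Nc1nc2c(c(-c3ccco3)cn2[C@@H]2O[C@H](CO)[C@@H](O)[C@H]2O)c(=O)[nH]1` is the next member; it differs from compound 2 by furan-2-yl in place of phenyl on an aromatic carbon. Among the measured compounds shown here, no step between two measured compounds is available, so the effect of this exchange in this assay is unknown; the expectation is for no step beyond the scatter in this assay. The expected step is a number no higher from compound 2 to compound 4 (the limit leaves the size open). Compound 4 is estimated at 100000 nM, between 50000 nM and 200000 nM, most likely reported again as a limit.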

Compound 4, half-maximal inhibitory concentration: > 100000 nM
Compound 4 was reported as a limit; the forecaster's own chance of this, stated with the estimate: 60%; the middle value lies on the limit itself.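

In this assay compound 4 gives > 100000 nM as a limit. Among these compounds, compound 2 is also a limit, so no step between compound 2 and compound 4 can be read: the limit of > 100000 nM in this assay, at which 2 of the 4 values shown sit.

Going by these compounds, whether furan-2-yl in place of phenyl changes the value in this assay stays open.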